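Branching the Amino Ester Chain of a Soluble Compound

The source may hold more compounds than are shown below. What is called first, only, known or untested is meant among the compounds shown, and "the series" means these compounds.

Compound 2 `Cc1c(C)c2c(c(C)c1OC(=O)CCCN)CC(CCn1ccc(=O)c(O)c1C)O2` is the anchor of this comparison. Going by the values given here, in an ADME assay for solubility (on this read-out lower numbers stand for lower solubility and higher numbers for higher solubility), compound 2 gives 10000 ug/mL, the only numerical value in the set. Compound 1 `Cc1c(C)c2c(c(C)c1OC(=O)c1ccc(N)cc1)CC(CCn1ccc(=O)c(O)c1C)O2` is reported in this assay only as a limit, < 100 ug/mL, not as a number. Among the compounds with values here, the single measured step, an at least 100-fold higher number from compound 1 to compound 2 (2.00 log units; beyond the scatter), is the only guide available, and it rests on (the limit of < 100 ug/mL in this assay, at which 1 of the 2 values shown sits).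

Compound 3 `Cc1c(C)c2c(c(C)c1OC(=O)C(N)C(C)C)CC(CCn1ccc(=O)c(O)c1C)O2` differs from compound 2 by 1-amino-2-methylpropyl in place of 3-aminopropyl on a carbonyl carbon. That step swapped an aromatic amine for an aliphatic amine chain, whereas here an aliphatic amine is kept and the chain is merely rearranged into a branched form, so the measured step bears only loosely on this change. The expected step from compound 2 to compound 3 in this assay is therefore a 1.7-fold lower number from compound 2 to compound 3 (0.22 log units; within the scatter), a change within the scatter or slightly downward. Compound 3 is estimated at 6000 ug/mL, with a range from 2000 ug/mL to 10000 ug/mL.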

Compound 3, solubility: > 20000 ug/mL
Compound 3: no number, only a limit; the forecaster's own chance of this, stated with the estimate: 20%; middle value at least 3.3-fold (0.52 log units) from the limit.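

In this assay compound 3 is reported only as a limit, > 20000 ug/mL. Within the aliphatic amine chains, the branched 1-amino-2-methylpropyl on the carbonyl carbon gives no lower number than the straight 3-aminopropyl: the step is an at least 2.0-fold higher number from compound 2 to compound 3 (0.30 log units; that floor lies within the scatter), so this change is tolerated, though the floor alone does not establish a real gain. The larger step is an at least 200-fold higher number from compound 1 to compound 3 (2.30 log units; beyond the scatter), which means that both aliphatic amine chains shown, straight and branched, now stand well clear of 4-aminophenyl at this position.

Going by these compounds, how far compound 3 lies past its limit stays open, and with it the true size of its step from compound 2. The compounds shown also leave open how a carboxylic acid in place of the amine, or a longer branched chain, would read in this assay.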